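The source may hold more compounds than are shown below. What is called first, only, known or untested is meant among the compounds shown, and "the series" means these compounds.

Measured in a functional assay on HepG2 cells (Homo sapiens) for antiproliferative activity, read by MTT assay, with a stated time of 48 h (a lower number here means a stronger inhibitor, a higher number a weaker inhibitor), so far:
- compound 1 `CC(=O)N1N=C(c2ccc3ccccc3c2)OC1c1ccc(F)cc1` gives 1.82 ug/mL in this series
- compound 2 `CC(=O)N1N=C(c2ccc3ccccc3c2)OC1c1ccc([N+](=O)[O-])cc1` gives 8.1 ug/mL in this series

Compound 2 holds the higher of the two numbers, which makes it the weaker inhibitor of the pair. Compound 3 `CC(=O)N1N=C(c2ccc3ccccc3c2)OC1c1ccc(OCc2ccccc2)cc1` has not yet been measured. It differs from compound 2 in one place, with benzyloxy in place of nitro on an aromatic carbon.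

Within the data shown here, only one measured step bears on this change, and it falls at the same place: a 4.5-fold higher number from compound 1 to compound 2 (0.65 log units; beyond the scatter) (modest, beyond the scatter), with nitro in place of fluoro. Among the measured compounds shown here, no compound with benzyloxy has been measured, so this step gives a likely size and only a weak hint of direction. A step of similar modest size or smaller is therefore expected in this assay, leaning toward a lower number, with no change beyond the scatter also possible. The expected step is a 1.6-fold lower number from compound 2 to compound 3 (0.21 log units; within the scatter) on this estimate. For compound 3 the estimated value is 5 ug/mL with an expected range of 1.5 ug/mL to 16 ug/mL for now.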

Compound 3, half-maximal inhibitory concentration: 3.38 ug/mL
Beside the measured number, compound 3's estimate is 1.5-fold (0.17 log units) above it; the measured number falls inside the stated range.
By their numbers in this assay, from the lowest: compounds 1 and 3 (each within the scatter of the next); then compound 2.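

In this assay, benzyloxy in place of nitro on this aromatic carbon, para to a large group, gives a 2.4-fold lower number from compound 2 to compound 3 (0.38 log units; beyond the scatter) and so shows that nitro can be replaced here by a much larger group, with 8 heavy atoms and a six-membered aromatic ring of its own, without the number rising. Set against fluoro at the same place, benzyloxy gives a 1.9-fold higher number from compound 1 to compound 3 (0.27 log units; within the scatter) and so leaves compound 1 and compound 3 level, which makes nitro the one group of the three that stands apart at this position, though only by a modest step. Nothing measured alongside these numbers explains why nitro stands apart from the other two groups.

As far as these compounds go, with only fluoro, nitro and benzyloxy at this place, it remains open whether a methoxy group, a hydroxyl, an amine or a carboxylic acid would sit with nitro or with the other two. From the compounds shown here alone, it is also open whether a chloro or methyl group on the outer ring of benzyloxy would shift the number at all, and whether the same order of the three groups would hold on a core with another group in place of the acetyl.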